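One Trifluoromethyl Exchange and the Expected Tolerated Concentration

The source may report more compounds than this note shows. Statements on the series, on what has been measured and on what is new or still open speak of the compounds shown alone.

Compound 1 `Nc1ccc2oc(-c3ccccc3)c(O)c(=O)c2c1` gives 217000 nM
Compound 2 `Nc1ccc2oc(-c3cccc(C(F)(F)F)c3)c(O)c(=O)c2c1` gives 8100 nM

Within the data shown here, in an ADME assay on MT4 cells (Homo sapiens) for cytotoxicity, read by MTT assay, with a stated time of 4 days (a higher number here means that more compound is tolerated, a lower number that less compound is tolerated), compound 1 stands at 217000 nM, the higher of the two numbers so far. Compound 3 `Nc1ccc2oc(-c3ccc(C(F)(F)F)cc3)c(O)c(=O)c2c1` has not yet been measured. It departs from compound 1 by one change: trifluoromethyl in place of hydrogen on an aromatic carbon. This places trifluoromethyl in place of hydrogen on an aromatic carbon, para to a large group.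

Among the measured compounds shown here, only one measured step bears on this change. It is a 27-fold lower number from compound 1 to compound 2 (1.43 log units; beyond the scatter), a large step beyond the scatter that also puts trifluoromethyl in place of hydrogen on an aromatic carbon. For the measured compounds named here, no measurement yet shows the group at the place it takes in compound 3, so the size of the step remains uncertain. A large step to a lower number is nevertheless expected, estimated as an 18-fold lower number from compound 1 to compound 3 (1.26 log units; beyond the scatter). The estimated value for compound 3 is 12000 nM, with an expected range from 3500 nM to 50000 nM.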

Compound 3, half-maximal cytotoxic concentration: 3900 nM
Compound 3: middle estimate off by 3.1-fold (0.49 log units), on the high side, and the stated range covers the measured number.
By their numbers in this assay, from the lowest: compound 3; then compound 2; then compound 1.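

With the trifluoromethyl group para to a large group, this assay records a 56-fold lower number from compound 1 to compound 3 (1.75 log units; beyond the scatter), so the large step is not confined to the placement in compound 2. Both trifluoromethyl compounds shown, compound 2 at 8100 nM and compound 3 at 3900 nM, therefore stand well under compound 1, and neither goes against this pattern across the three compounds. No measurement offered here explains why this exchange lowers the tolerated concentration.

The compounds shown leave open whether a fluorine atom, a methyl group or a carboxylic acid at this same place would lower the number as far as trifluoromethyl does. They also leave open whether a trifluoromethyl group on any other carbon of that ring would give a similar step.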